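Oxazolidinone ring nitrogen: methyl against hydrogen

The compounds below may be only part of what the source reports. "The series", "measured", "known", "first", "only" and "open" are said of these compounds alone.

Of the compounds shown here, two have been measured so far. Compound 1 `CN(C)C[C@@H]1CN(C)C(=O)O1` was tested in an assay on Hippocampus for displacement of a labelled ligand from Neuronal acetylcholine receptor; alpha4/beta2 (Rattus norvegicus) (a higher number here means a weaker inhibitor, a lower number a stronger inhibitor), and gives 2660 nM. Compound 2 `CN1C[C@@H](C[N+](C)(C)C)OC1=O` carries a group of 4 heavy atoms (3 carbon, 1 nitrogen; no ring) in place of the group of 3 heavy atoms on the side chain; in this assay compound 2 gives 3610 nM. The step of a 1.4-fold higher number from compound 1 to compound 2 (0.13 log units; within the scatter) lies within the scatter, so the two numbers cannot be told apart. Among the two values, compound 1 shows the lower one, but only by a margin that means nothing.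

Compound 3 `CN(C)C[C@@H]1CNC(=O)O1` is not yet measured. It differs from compound 1 in one place: hydrogen in place of methyl on an amide-type nitrogen in a ring. Among the measured compounds shown here, no measured step touches this part of the shared core of compound 1; the only step available concerns the side chain, and it stayed within the scatter. There is therefore no measured ground for expecting a step in this assay in either direction, and the step of a 1.0-fold higher number from compound 1 to compound 3 (0.01 log units; within the scatter) is expected to stay within the scatter. For compound 3 the estimated value in this assay is 2700 nM, with a range from 900 nM to 8000 nM.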

Compound 3, inhibition constant: 452 nM
Estimate against measurement, compound 3: 6.0-fold (0.78 log units) above, and the stated range ends above it.
By their numbers in this assay, from the lowest: compound 3; then compounds 1 and 2 (each within the scatter of the next).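

In this assay, hydrogen in place of methyl on the amide-type nitrogen in a ring gives a 5.9-fold lower number from compound 1 to compound 3 (0.77 log units; beyond the scatter). Among the compounds shown here, this is the only step so far that lies beyond the scatter, whereas the side-chain change, a 1.4-fold higher number from compound 1 to compound 2 (0.13 log units; within the scatter), could not be read, so this nitrogen of the shared core is a place where the number does respond, and the loss of a single methyl is enough to move it. Nothing measured here accounts for the size or direction of this step.

With only methyl and hydrogen shown on this nitrogen, it remains open how an ethyl group or a longer chain at the same place would compare with either of them. Going by these compounds, it is also open whether hydrogen on this nitrogen would give a similar step alongside the side chain of compound 2, or alongside a different side chain such as a primary amine.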